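The source may hold more compounds than are shown below. What is called first, only, known or untested is meant among the compounds shown, and "the series" means these compounds.

Measured so far:
compound 1 `CNC(=O)[C@H](c1ccc(Cl)cc1)C(C)C`: 11000 nM
compound 2 `CC(C)[C@H](C(=O)NC(C)(C)C)c1ccc(Cl)cc1`: > 100000 nM

In a functional assay on CHO cells for agonist activity at Free fatty acid receptor 2 (Homo sapiens), read by cAMP accumulation (a higher number here means a weaker inhibitor, a lower number a stronger inhibitor), compound 1 gives 11000 nM. For compound 2 this assay reports only a limit, > 100000 nM, so its true position is a bound rather than a number. For the measured compounds named here, the one measured step shows an at least 9.0-fold higher number from compound 1 to compound 2 (0.95 log units; beyond the scatter), and compound 2 sits at the limit of > 100000 nM in this assay, at which 1 of the 2 values shown sits.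

Compound 3 `CC(C)[C@H](C(=O)NCc1ccccc1)c1ccc(Cl)cc1` differs from compound 2 by benzyl in place of tert-butyl on an amide-type nitrogen. Going by the values given here, the only step that bears on this change is the exchange of methyl for tert-butyl on the same amide-type nitrogen, an at least 9.0-fold higher number from compound 1 to compound 2 (0.95 log units; beyond the scatter), where the bulkier group weakened the compound. Benzyl is a different kind of group, and no measured pair contains one, so the direction of this step is open. Compound 3 is therefore expected to remain weak, with an estimate of 50000 nM (range 8000 nM to 300000 nM). The estimated change is an at least 2.0-fold lower number from compound 2 to compound 3 (0.30 log units; that floor lies within the scatter), and a further limit rather than a number is quite possible.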

Compound 3, half-maximal inhibitory concentration: > 100000 nM
Compound 3 was reported as a limit; the forecaster's own chance of this, stated with the estimate: 45%; middle value at least 2.0-fold (0.30 log units) from the limit.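

In this assay, compound 3 is reported only as a limit, so the comparison with compound 2 joins two limits and that step cannot be read. Against compound 1, phenyl in place of hydrogen on the saturated chain carbon bound to the amide-type nitrogen gives an at least 9.0-fold higher number from compound 1 to compound 3 (0.95 log units; beyond the scatter), so a weaker result now appears with a ring-bearing benzyl group as well as with branched tert-butyl. Of the three compounds, only the one carrying methyl on this nitrogen gives a number, while the other two share a single limit: the limit of > 100000 nM in this assay, at which 2 of the 3 values shown sit.

On these data alone, how ethyl, or a plain amide hydrogen in place of methyl, would read at this nitrogen stays open. So does whether a carboxylic acid or an amine on the benzyl ring would lower the number.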